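This account rests on a few compounds, and the source may have more. Where it says the series, first, only, none or still open, it means among the compounds named here.

Compound 1 `O=C(CCCCC1CCSS1)NCc1cn(CCCOc2ccc3ccc(=O)oc3c2)nn1` gives 39.2% in a functional assay on PC-12 cells (Rattus norvegicus) for cytotoxicity, read by MTT assay, with stated times of 3 h and 2 h, tested at 5 uM; on this read-out higher numbers stand for a stronger effect at the one concentration tested and lower numbers for a weaker effect. Compound 2 `O=C(CCCCC1CCSS1)NCc1cn(CCCOc2ccc3cc(-c4ccc(Br)cc4)c(=O)oc3c2)nn1` gives 57.3% in this assay and stands highest of the two numbers; the gain a number 18.1 percentage points higher from compound 1 to compound 2 (beyond the scatter) lies beyond the scatter. Compound 3 `O=C(CCCCC1CCSS1)NCc1cn(CCCOc2ccc3cc(-c4ccc(Cl)c(Cl)c4)c(=O)oc3c2)nn1` differs from compound 2 by 3,4-dichlorophenyl in place of 4-bromophenyl on an aromatic carbon. Going by the values given here, no measured step swaps one substituted phenyl for another: the only step seen, a number 18.1 percentage points higher from compound 1 to compound 2 (beyond the scatter), introduces the phenyl itself and so bears on this change only loosely. The step of a number 0.7 percentage points higher from compound 2 to compound 3 (within the scatter) is therefore expected to stay within the scatter. Compound 3 is estimated at 58%, between 42% and 74%.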

Compound 3, a percentage reported as activity, at one concentration (the size of the read-out at that concentration, not a potency): 44.7%
For compound 3 the middle estimate is 13.3 percentage points above the measured one; the range from low to high includes it.
By their numbers in this assay, from the lowest: compounds 1 and 3 (each within the scatter of the next); then compound 2.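

In this assay, the position responds to what the phenyl carries, not merely to the presence of a phenyl: 3,4-dichlorophenyl in place of 4-bromophenyl gives a number 12.6 percentage points lower from compound 2 to compound 3 (beyond the scatter). Set against hydrogen at the same aromatic carbon, 3,4-dichlorophenyl gives a number 5.5 percentage points higher from compound 1 to compound 3 (within the scatter), so the gain seen with 4-bromophenyl does not carry over to this group.

On these data alone, whether the drop follows the loss of bromine or the presence of two chlorines stays open, and 4-chlorophenyl would separate the two. Phenyl groups bearing an amine or a carboxylic acid also remain untested in the compounds shown, and no evidence here bears on the reason for the drop.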